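Swapping the aryl partner on a low-solubility sulfonamide

The source may report more compounds than this note shows. Statements on the series, on what has been measured and on what is new or still open speak of the compounds shown alone.

Compound 2 `O=S(=O)(Nc1nccs1)c1ccc2c(c1)OCC[C@@H]2c1ccc(C(F)(F)F)cc1-c1ccc(F)cn1` stands lowest of the three numbers measured in a physicochemical assay for solubility (on this read-out higher numbers stand for higher solubility and lower numbers for lower solubility), where compound 2 gives 7000 nM. Compound 3 `O=S(=O)(Nc1ncccn1)c1ccc2c(c1)OCC[C@@H]2c1ccc(C(F)(F)F)cc1-c1ccc(F)cn1` gives 225000 nM in this assay, and compound 1 `Cn1nccc1-c1cc(C(F)(F)F)ccc1[C@H]1CCOc2cc(S(=O)(=O)Nc3ccncn3)ccc21` gives 1180000 nM. Among the measured compounds shown here, the only step between neighbours, a 32-fold higher number from compound 2 to compound 3 (1.51 log units; beyond the scatter), concerns the group on the sulfonamide nitrogen and is the single measured change in this set; compound 1 differs from compound 3 in a further place, so its higher number is not tied to one change.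

Compound 4 `O=S(=O)(Nc1nccs1)c1ccc2c(c1)OCC[C@@H]2c1ccc(C(F)(F)F)cc1-n1ccnn1` is the next compound to be measured. It differs from compound 2 in one place: 1H-1,2,3-triazol-1-yl in place of 5-fluoropyridin-2-yl on an aromatic carbon. The change sits on an aromatic carbon of a six-membered aromatic ring of carbon only, ortho to a large group and meta to a trifluoromethyl group. For the measured compounds named here, no measured step touches this position, so the expectation rests only on the low starting point of compound 2. Compound 4 is therefore expected to show a modest rise in this assay, a 5.0-fold higher number from compound 2 to compound 4 (0.70 log units; beyond the scatter), with an estimated 35000 nM and a range from 7000 nM to 200000 nM.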

Compound 4, solubility: 171000 nM
Compound 4: the middle estimate sits 4.9-fold (0.69 log units) below what was measured; the measured number falls inside the stated range.
By their numbers in this assay, from the lowest: compound 2; then compounds 4 and 3 (each within the scatter of the next); then compound 1.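

Compound 2 now has two single changes, in different places, that each give a large step. At the aromatic carbon ortho to a large group and meta to a trifluoromethyl group, the step is a 24-fold higher number from compound 2 to compound 4 (1.39 log units; beyond the scatter) in this assay, so this position, untouched by the earlier steps, is shown to move the read-out well beyond the scatter. The change exchanges a six-membered aromatic ring with 1 hetero atom for a five-membered aromatic ring with 3 hetero atoms, and no information here accounts for the size of the step.

This single step cannot separate ring size from the number of ring nitrogens or the loss of fluorine, and 1H-1,2,3-triazol-1-yl is seen here only with 1,3-thiazol-2-yl on the sulfonamide nitrogen. From the compounds shown here alone, how an amine, a carboxylic acid or a methoxy group at this position would read remains open.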